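Swapping a tetrahydrofuranyl carbinol for a dimethylisoxazole

The source may report more compounds than this note shows. Statements on the series, on what has been measured and on what is new or still open speak of the compounds shown alone.

Measured compounds:
- compound 1, `Cc1cc(C)c(CN2CCc3c(Cl)cc([C@H](CO)[C@H]4CCCO4)c(Cl)c3C2=O)c(=O)[nH]1`: 2.1
- compound 2, `CCOC(c1cc(Cl)c2c(c1Cl)C(=O)N(Cc1c(C)cc(C)[nH]c1=O)CC2)C1CS(=O)(=O)C1`: 2.4; 2.3 (2 entries)

In a physicochemical assay for lipophilicity, at pH 7.4 (a lower number here means a more polar compound, a higher number a more lipophilic compound), compound 1 gives 2.1, the only number shown for it here. Among the compounds with values here, compound 2 was measured more than once in this assay, (the several entries of compound 2 in this assay, 2.4; 2.3 (2 entries)), and the two compounds differ in more than one place, so no single step between them is counted. The unmeasured compound 3, `Cc1cc(C)c(CN2CCc3c(Cl)cc(-c4c(C)noc4C)c(Cl)c3C2=O)c(=O)[nH]1`, shares the core of compound 1 and differs from it in one place: a group of 7 heavy atoms (5 carbon, 1 nitrogen, 1 oxygen; one five-membered aromatic ring with 2 hetero atoms) in place of a group of 8 heavy atoms (6 carbon, 2 oxygen; one five-membered non-aromatic ring with 1 hetero atom), on an aromatic carbon. The group that leaves carries the only hydrogen-bond donor of that part of the molecule, while the entering aromatic ring carries none. Such a change is expected to push this assay upward by more than the usual scatter, with an expected step of a number 0.80 log units higher from compound 1 to compound 3 (beyond the scatter). Compound 3 is therefore estimated at 2.9, most likely between 2.4 and 3.4.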

Compound 3, distribution coefficient: 3.1
Compound 3: the middle estimate sits 0.20 log units below what was measured; low and high end bracket the measured number.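

The aromatic carbon of the shared core that carries this group, ortho to a chloro group, clearly matters for this assay: replacing the tetrahydrofuranyl carbinol with 3,5-dimethyl-1,2-oxazol-4-yl gives a number 1.00 log units higher from compound 1 to compound 3 (beyond the scatter). Within the data shown here, compound 1 and compound 2 differ in more than one place, so this pair gives the first direct reading of a change at this position. The step also stands well clear of the spread seen when a single compound is read more than once: the several entries of compound 2 in this assay, 2.4; 2.3 (2 entries)

Among these compounds, with only one pair, it remains open whether the shift follows the hydrogen-bond donor that leaves, the aromatic ring that enters, or both together. On these data alone, how an amine, a carboxylic acid or a plain methyl group on this carbon would read in this assay also remains open.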